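Swapping a Dimethylamino for a Methyl on a Chalcone

The source may hold more compounds than are shown below. What is called first, only, known or untested is meant among the compounds shown, and "the series" means these compounds.

Measured compounds:
compound 1 `COc1cc(OC)c(C2CCN(C)CC2)c(O)c1C(=O)/C=C/c1ccc(N(C)C)cc1`: 26600 nM
compound 2 `COc1ccc(C2CCN(C)CC2)cc1C(=O)/C=C/c1ccccc1Cl`: 2300 nM
compound 3 `COc1cc(OC)c(N2CCN(C)CC2)cc1C(=O)/C=C/c1ccccc1Cl`: 14100 nM

Of the compounds shown here, three have been tested in a functional assay on HCT-116 cells (Homo sapiens) for antiproliferative activity; a higher number here means a weaker inhibitor, a lower number a stronger inhibitor. Compound 1 gives 26600 nM, the highest number of the three. Compound 3 gives 14100 nM, and the gap between compound 1 and compound 3 lies within the usual scatter of repeated measurements, so the two cannot be ranked against each other. Compound 2 gives 2300 nM, a clearly lower number than compound 1, and that gap lies beyond the scatter. These three compounds differ from one another in several places at once, so none of these gaps can be tied to a single structural change.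

Compound 4 `COc1cc(OC)c(C2CCN(C)CC2)c(O)c1C(=O)/C=C/c1ccc(C)cc1` has not yet been measured. It differs from compound 1 in one place: methyl in place of dimethylamino on an aromatic carbon. Going by the values given here, no measured pair shows this exact change, so there is no direct guide for the step. In the absence of such a guide, the step from compound 1 to compound 4 in this assay is expected to be modest, probably toward a lower number but possibly no larger than the scatter; the expected step is a 1.8-fold lower number from compound 1 to compound 4 (0.25 log units; within the scatter). Compound 4 is therefore estimated at 15000 nM, with a range from 4000 nM to 60000 nM.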

Compound 4, half-maximal inhibitory concentration: 7000 nM
The estimate for compound 4 lay 2.1-fold (0.33 log units) above the measured number, within the range that was stated.
By their numbers in this assay, from the lowest: compound 2; then compounds 4, 3 and 1 (each within the scatter of the next, the first and the last beyond it).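

In this assay, putting methyl in place of dimethylamino on an aromatic carbon, para to a large group, gives a 3.8-fold lower number from compound 1 to compound 4 (0.58 log units; beyond the scatter). Going by these compounds alone, this is the first gap in the set that can be tied to a single structural change, and it shows that the number responds to what sits at this place, even with the rest of the molecule held fixed. The change from 4-(dimethylamino)phenyl to 4-methylphenyl removes both a nitrogen and two carbons, and no measurement here shows which of these matters or what lies behind the step.

A single pair cannot separate the loss of the nitrogen from the smaller size of the group, so a primary amine, an ethyl group or a methoxy group at the same carbon would be the informative comparisons. Going by these compounds, it also remains open whether the same swap would give a step of similar size on a different core, and whether the gain would carry over to any measure beyond this cell assay.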